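The compounds below may be only part of what the source reports. "The series", "measured", "known", "first", "only" and "open" are said of these compounds alone.

Measured so far:
Compound 1, `CCCCCCCCCCC#CCOCc1ccc(CCCC(=O)O)cc1`; in an assay on isolated protein for inhibition of Arachidonate 12-lipoxygenase (Sus scrofa) (a lower number here means a stronger inhibitor, a higher number a weaker inhibitor), compound 1 gives only a limit, > 10000 nM.
Compound 2, `CCCCCCCCC#CCOCc1ccc(CCC(=O)O)cc1`; in this assay compound 2 gives 100 nM.

Among the compounds with values here, compound 2 holds the only numerical value; the one further value is a limit (the limit of > 10000 nM in this assay, at which 1 of the 2 values shown sits), and no single step connects compound 1 and compound 2, which differ in more than one place. Within the data shown here, the series therefore supplies no measured step on which to rest.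

Compound 3 is `CCCCCCCCCCCCCCC#CCOCc1ccc(CCC(=O)O)cc1`. Against compound 2 the change is hexyl in place of hydrogen on a saturated chain carbon, eight bonds along the chain from a triple-bonded carbon. Compound 1, which also carries a longer saturated chain than compound 2 among its differences, sits only at the limit (the limit of > 10000 nM in this assay, at which 1 of the 2 values shown sits), and that is the sole hint available on how added chain length is tolerated in this assay.

The expected step of a 25-fold higher number from compound 2 to compound 3 (1.40 log units; beyond the scatter) runs toward weaker inhibition and beyond the scatter, with wide uncertainty. Compound 3 is expected to give 2500 nM in this assay, with a range from 300 nM to 15000 nM.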

Compound 3, half-maximal inhibitory concentration: > 10000 nM
Compound 3: a limit, no number (the forecaster's own chance of this, stated with the estimate: 35%); middle value at least 4.0-fold (0.60 log units) from the limit.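

Hexyl in place of hydrogen on a saturated chain carbon, eight bonds along the chain from a triple-bonded carbon, gives an at least 100-fold higher number from compound 2 to compound 3 (2.00 log units; beyond the scatter) in this assay, which is the first step in the series that changes one place only and a large one, beyond the scatter. Compound 3 gives a limit and not a number, so the step has a bound and no exact size. At this position, the full hexyl extension of the chain of compound 2 is therefore not tolerated without a large loss of inhibition, and most of the series now rests at the limit: the limit of > 10000 nM in this assay, at which 2 of the 3 values shown sit.

The compounds shown leave open how the number moves along the chain lengths between those of compound 2 and compound 3, for example with a methyl, an ethyl or a propyl in place of the same hydrogen, and whether any of these would keep the value of compound 2. Also open, as far as these compounds go, is whether a chain shorter than that of compound 2, or a hydroxyl or an amine at the far end of the longer chain, would change the outcome in this assay at this position.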